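This account rests on a few compounds, and the source may have more. Where it says the series, first, only, none or still open, it means among the compounds named here.

Compound 1 `Cc1ccc(N2CCN(C(=O)c3oc(C)nc3-c3ccccc3)CC2)cc1`: > 1000 nM
Compound 2 `Cc1nc(-c2ccccc2)c(C(=O)N2CCN(c3ccccc3C(F)(F)F)CC2)o1`: 120 nM

Both compounds were tested in a functional assay on HL-60 cells (Homo sapiens) for inhibition, read by MTT assay, with a stated time of 72 h; a higher number here means a weaker inhibitor, a lower number a stronger inhibitor. For compound 1, the entry > 1000 nM is a limit of the assay and not a number. Among the compounds with values here, compound 2, at 120 nM, therefore holds the only actual number so far.

Compound 3 `Cc1nc(-c2ccccc2)c(C(=O)N2CCN(c3cccc(C(F)(F)F)c3)CC2)o1` carries 3-(trifluoromethyl)phenyl in place of 2-(trifluoromethyl)phenyl on an amine nitrogen in a ring. The two have the same atoms, joined differently: 3-(trifluoromethyl)phenyl in place of 2-(trifluoromethyl)phenyl on an amine nitrogen in a ring.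

Within the data shown here, only one measured step bears on this change. It is an at least 8.3-fold lower number from compound 1 to compound 2 (0.92 log units; beyond the scatter), with 2-(trifluoromethyl)phenyl in place of 4-methylphenyl at the same nitrogen. That step changed both the group and its place on the aromatic ring, so it does not isolate the effect of position. It does show that compound 2 owes its number in this assay to a change at this site, so some loss is expected when the group moves, though with wide uncertainty. The expected change is a 2.1-fold higher number from compound 2 to compound 3 (0.32 log units; beyond the scatter), a modest move toward a weaker inhibitor. The estimated value for compound 3 is 250 nM, with an expected range of 70 nM to 900 nM.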

Compound 3, half-maximal inhibitory concentration: 153 nM
For compound 3 the middle estimate is 1.6-fold (0.21 log units) above the measured one, within the range that was stated.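

In this assay, within the data shown here, the step with the group's place as the only change is a 1.3-fold higher number from compound 2 to compound 3 (0.11 log units; within the scatter), so 2-(trifluoromethyl)phenyl and 3-(trifluoromethyl)phenyl cannot be told apart at this amine nitrogen. The earlier step had changed both the group and its place, whereas this pair keeps the group and shows that, for these two compounds, the reading in this assay holds when the trifluoromethyl group moves on the aromatic ring. Replacing 4-methylphenyl with 3-(trifluoromethyl)phenyl gives an at least 6.5-fold lower number from compound 1 to compound 3 (0.81 log units; beyond the scatter), which, like the earlier step from the same starting point, is a bound and not an exact size, since one end of it is a limit of the assay and not a number: the limit of > 1000 nM in this assay, at which 1 of the 3 values shown sits.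

From the compounds shown here alone, whether the difference from compound 1 follows the trifluoromethyl group itself or its place on the aromatic ring stays open. Also open, going by these compounds, is how a chlorine atom, a nitrile or a plain unsubstituted phenyl would read at this nitrogen in this assay.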